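Swapping an Ethyl for a Pyridine on the Ring Amide

The source may hold more compounds than are shown below. What is called first, only, known or untested is meant among the compounds shown, and "the series" means these compounds.

Compound 1 `CCCCNc1nc(N)nc2c1CNCC2` gives 7.2 uM in an assay on HEK293 cells for agonist activity at Toll-like receptor 8 (Homo sapiens), read by a luciferase reporter, with a stated time of 6 h; on this read-out lower numbers stand for an effect already at smaller amounts and higher numbers for an effect only at larger amounts of compound. For the measured compounds named here, compound 2 `CCCCNc1nc(N)nc2c1CN(C(=O)CC)CC2` gives 0.4 uM, the lowest of the two numbers so far; the one step measured, an 18-fold lower number from compound 1 to compound 2 (1.26 log units; beyond the scatter), goes with propanoyl in place of hydrogen on an amine nitrogen in a ring. Compound 3 `CCCCNc1nc(N)nc2c1CN(C(=O)c1ccncc1)CC2` differs from compound 2 only at that amide: pyridin-4-yl in place of ethyl on a carbonyl carbon. No measured step exchanges groups on this carbonyl carbon, so nothing shown speaks for a shift beyond the scatter. Compound 3 is thus expected at 0.4 uM, between 0.1 uM and 1.6 uM, an expected step of no change at the digits printed from compound 2 to compound 3 (within the scatter).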

Compound 3, minimum effective concentration: > 25 uM
Compound 3 ended at the assay's limit; the forecaster's own chance of this, stated with the estimate: 5%; middle value at least 62-fold (1.79 log units) from the limit.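

The carbonyl carbon of the ring amide proves sensitive to the group it carries: pyridin-4-yl in place of ethyl brings a large loss (an at least 62-fold higher number from compound 2 to compound 3 (1.79 log units; beyond the scatter)). An acyl group on the ring nitrogen is therefore no gain in itself, as (pyridin-4-yl)carbonyl in place of hydrogen moves the number the opposite way to propanoyl (an at least 3.4-fold higher number from compound 1 to compound 3 (0.54 log units; beyond the scatter)). The number for compound 3 is a limit, not a measured value: the limit of > 25 uM in this assay, at which 1 of the 3 values shown sits.

Still open, as far as these compounds go, is whether the loss follows the ring itself or its nitrogen, which a phenyl group on the same carbonyl carbon could separate. Also open, from the compounds shown here alone, is whether a longer chain, such as butyl, would keep the low number of compound 2.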